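Swapping the nitro for a bromo on the benzyl arm

The source may hold more compounds than are shown below. What is called first, only, known or untested is meant among the compounds shown, and "the series" means these compounds.

Measured so far:
Compound 1 `Cc1ccc(Cn2cc(COc3ccc4c(=O)ccoc4c3)nn2)cc1`: > 100000 nM
Compound 2 `N#Cc1ccc(Cn2cc(COc3ccc4c(=O)ccoc4c3)nn2)cc1`: > 100000 nM
Compound 3 `O=c1ccoc2cc(OCc3cn(Cc4ccc([N+](=O)[O-])cc4)nn3)ccc12`: 71300 nM

In a functional assay on MDA-MB-231 cells (Homo sapiens) for cytotoxicity, read by MTT assay, with a stated time of 48 h (a lower number here means a stronger inhibitor, a higher number a weaker inhibitor), compound 1 returns only a limit of the assay, > 100000 nM, and no number. Compound 2 likewise sits at a limit in this assay, > 100000 nM. Compound 3 is the only one of the three with a real number, 71300 nM, so it stands as the sole measured point. The values of compound 1 and compound 2 are limits of the assay, as shown by the limit of > 100000 nM in this assay, at which 2 of the 3 values shown sit.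

Compound 4 `O=c1ccoc2cc(OCc3cn(Cc4ccccc4Br)nn3)ccc12` follows from compound 3 through the change (2-bromophenyl in place of 4-nitrophenyl on a saturated chain carbon bound to an aromatic nitrogen).

Among the measured compounds shown here, no measured step exchanges a nitro for a bromo, so none bears on this change directly. The nearest comparisons are an at least 1.4-fold lower number from compound 1 to compound 3 (0.14 log units; that floor lies within the scatter) and an at least 1.4-fold lower number from compound 2 to compound 3 (0.14 log units; that floor lies within the scatter), each a floor that lies within the scatter; both show that taking the nitro away leads back toward the limit. The change to compound 4 also removes the nitro, so the expected step in this assay is a 1.7-fold higher number from compound 3 to compound 4 (0.23 log units; within the scatter), that is, a weaker inhibitor and quite possibly another limit.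

The estimate for compound 4 in this assay is 120000 nM, with a range from 50000 nM to 300000 nM.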

Compound 4, half-maximal inhibitory concentration: > 100000 nM
Compound 4 ended at the assay's limit; the forecaster's own chance of this, stated with the estimate: 55%; the middle value is on the limit's open side.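

In this assay, placing 2-bromophenyl where 4-nitrophenyl stood gives an at least 1.4-fold higher number from compound 3 to compound 4 (0.14 log units; that floor lies within the scatter), so this change brings no measurable gain, and the floor cannot say how large the true step is. The earlier compounds shown here varied only the group carried in the 4-position of the phenyl ring, whereas compound 4 shows that a 2-bromophenyl on this saturated chain carbon bound to an aromatic nitrogen also gives no readable value; the steps from compound 1 and from compound 2 to compound 4 cannot be read, as both ends of each are limits. Of the four compounds, only compound 3, with its 4-nitrophenyl, keeps a measured number, and the others share a limit: the limit of > 100000 nM in this assay, at which 3 of the 4 values shown sit.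

Compound 4 changes both the group and its place on the ring at once, so the compounds shown do not separate the effect of the bromine from the effect of where it sits. As far as these compounds go, it also remains open whether an amine or a carboxylic acid on this ring, or a longer chain joining the ring to the aromatic nitrogen, would give a readable value in this assay.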